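Amide series: replacing ethyl on the core with an anilino group

The source may report more compounds than this note shows. Statements on the series, on what has been measured and on what is new or still open speak of the compounds shown alone.

Among the measured compounds shown here, compound 2 `CCCOc1ccc(C(=O)Nc2cccc(CC)n2)cc1` gives 29200 nM in an in vitro assay on HEK-tsA201 cells for antagonist activity at Neuronal acetylcholine receptor; alpha3/beta4 (Homo sapiens), read by fluorescence and calcium flux (on this read-out lower numbers stand for stronger inhibition and higher numbers for weaker inhibition), the highest of the two numbers so far; the nearest is compound 1 `C=CCOc1ccc(C(=O)Nc2cccc(CC)n2)cc1`, which gives 27400 nM, and the step of a 1.1-fold higher number from compound 1 to compound 2 (0.03 log units; within the scatter) stays within the scatter. The next compound, compound 3 `CCCOc1ccc(C(=O)Nc2cccc(Nc3ccc(Cl)cc3)n2)cc1`, is not yet measured; it differs from compound 2 by (4-chlorophenyl)amino in place of ethyl on an aromatic carbon. For the measured compounds named here, no measured step touches this position: the only step known changes the chain on the oxygen, not the group on the core, and it was flat anyway. The change here is far larger than that one, so the outcome is open in both directions. Compound 3 is estimated at 20000 nM, with a range from 3000 nM to 100000 nM. The expected step is thus a 1.5-fold lower number from compound 2 to compound 3 (0.16 log units; within the scatter), with wide uncertainty, and a reported limit is possible.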

Compound 3, half-maximal inhibitory concentration: > 100000 nM
Compound 3 ended at the assay's limit (the forecaster's own chance of this, stated with the estimate: 20%); middle value at least 5.0-fold (0.69 log units) from the limit.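

Unlike the change on the oxygen chain, a 1.1-fold higher number from compound 1 to compound 2 (0.03 log units; within the scatter), the group on the aromatic carbon next to the ring nitrogen moves the read-out in this assay beyond the scatter: an at least 3.4-fold higher number from compound 2 to compound 3 (0.53 log units; beyond the scatter). For compound 3, > 100000 nM is a limit of the assay and not a number. The step therefore fixes only a minimum size and a direction, towards weaker inhibition, and it rests on that ceiling: the limit of > 100000 nM in this assay, at which 1 of the 3 values shown sits.

As far as these compounds go, how much of the step belongs to the added ring, the linking amine or the chlorine stays open, since all three enter together. Also open, from the compounds shown here alone, is whether a plain amine, a methyl or an unsubstituted phenylamino group at this position would stay close to compound 2, and whether a longer chain on the oxygen would change the picture.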